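A few compounds are considered here, and "the series" means these few. Any claim that something is new, unique, unknown or untested is made for them only; others in the source may bear on it.

Working notes on the series. Within the data shown here, in a functional assay on HCT-116 cells (Homo sapiens) for antiproliferative activity, read by MTT assay (on this read-out lower numbers stand for stronger inhibition and higher numbers for weaker inhibition), compound 2 `Cn1c(=O)c(=O)n(C2CCCC2)c2nc(N/N=C/c3ccc(F)c(Cl)c3)ncc21` gives 9020 nM, the only number in this set. Compound 1 `Cn1c(=O)c(=O)n(C2CCCC2)c2nc(N/N=C/c3ccccc3)ncc21` reaches only a limit, > 100000 nM. Compound 3 `COc1ccc(/C=N/Nc2ncc3c(n2)n(C2CCCC2)c(=O)c(=O)n3C)c(OC)c1` likewise reaches only a limit, > 100000 nM. Both steps away from compound 2 are therefore read against the limit of > 100000 nM in this assay, at which 2 of the 3 values shown sit: an at least 11-fold lower number from compound 1 to compound 2 (1.04 log units; beyond the scatter), and an at least 11-fold higher number from compound 2 to compound 3 (1.04 log units; beyond the scatter). Compound 4 `Cn1c(=O)c(=O)n(C2CCCC2)c2nc(N/N=C/c3ccccc3Cl)ncc21` differs from compound 2 by 2-chlorophenyl in place of 3-chloro-4-fluorophenyl on a carbon with a double bond to nitrogen. Among the measured compounds shown here, only the step from compound 1 to compound 2 bears on a halogenated phenyl, and it was large; a single chlorine without the fluorine gives no measured guide, so a modest loss toward the limit is expected. Compound 4 is estimated at 25000 nM, range 6000 nM to 100000 nM. The expected step is a 2.8-fold higher number from compound 2 to compound 4 (0.44 log units; beyond the scatter).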

Compound 4, half-maximal inhibitory concentration: 14000 nM
For compound 4 the middle estimate is 1.8-fold (0.25 log units) above the measured one; low and high end bracket the measured number.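

In this assay, chloro in place of hydrogen on an aromatic carbon is enough on its own to give an at least 7.1-fold lower number from compound 1 to compound 4 (0.85 log units; beyond the scatter), and 2-chlorophenyl in place of 2,4-dimethoxyphenyl gives an at least 7.1-fold lower number from compound 3 to compound 4 (0.85 log units; beyond the scatter). With 2-chlorophenyl in place of 3-chloro-4-fluorophenyl, a 1.6-fold higher number from compound 2 to compound 4 (0.19 log units; within the scatter) leaves these two halogenated phenyls indistinguishable, so the fluorine is not required for a measurable value. The two larger steps start from a limit, so their full size cannot be read: the limit of > 100000 nM in this assay, at which 2 of the 4 values shown sit.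

As far as these compounds go, whether fluorine alone would serve as chlorine does remains open. So does whether a phenyl carrying an amine or a carboxylic acid would give a measurable value, as the two halogenated phenyls do.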